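The compounds below may be only part of what the source reports. "The series", "measured", "known", "first", "only" and "open" are said of these compounds alone.

Three compounds share one core and differ only in the group on an amide-type nitrogen in a ring. In a functional assay on HOS-TE85 cells (Homo sapiens) for inhibition, read by CCK-8 assay, with a stated time of 72 h (on this read-out higher numbers stand for weaker inhibition and lower numbers for stronger inhibition), compound 1 (`O=C(NCCCCc1ccccc1)c1cccc(C2SCC(=O)N2c2cnccn2)c1`), which carries pyrazin-2-yl there, gives > 1000 nM, which is a limit of the assay and not a number. Within the data shown here, compound 2 (`COc1c(F)cccc1N1C(=O)CSC1c1cccc(C(=O)NCCCCc2ccccc2)c1`), with 3-fluoro-2-methoxyphenyl, gives 26.2 nM, the only true number so far. Among the measured compounds shown here, the one measured step bearing on the question is an at least 38-fold lower number from compound 1 to compound 2 (1.58 log units; beyond the scatter), so swapping a ring containing hetero atoms for this substituted phenyl made a large difference.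

Compound 3 (`O=C(NCCCCc1ccccc1)c1cccc(C2SCC(=O)N2c2nccs2)c1`) brings a change back in the other direction: 1,3-thiazol-2-yl in place of 3-fluoro-2-methoxyphenyl on an amide-type nitrogen in a ring. Here 1,3-thiazol-2-yl is not the same group as pyrazin-2-yl, but it is also an aromatic ring with hetero atoms, so the step seen with compound 1 is the best available guide. A single pair is thin evidence, and the size is therefore uncertain. The expected move is a large one towards a higher number, meaning weaker inhibition, and is estimated as a 19-fold higher number from compound 2 to compound 3 (1.28 log units; beyond the scatter). For compound 3 the estimated value is 500 nM, within an expected range of 90 nM to 2500 nM.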

Compound 3, half-maximal inhibitory concentration: > 1000 nM
Compound 3: only a limit was reported; the forecaster's own chance of this, stated with the estimate: 40%; at least 2.0-fold (0.30 log units) between middle value and limit.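

In this assay, putting 1,3-thiazol-2-yl on the amide-type nitrogen in a ring in place of 3-fluoro-2-methoxyphenyl gives an at least 38-fold higher number from compound 2 to compound 3 (1.58 log units; beyond the scatter), so the large step seen with pyrazin-2-yl is not tied to that one ring: among the three compounds shown, both aromatic rings with hetero atoms lie far from the carbon-only substituted phenyl on this read-out. Compound 3 gives > 1000 nM, which is a limit of the assay and not a number. The step between the two hetero-atom rings cannot be read, and neither ring can be placed ahead of the other, because both compounds sit at the same limit: the limit of > 1000 nM in this assay, at which 2 of the 3 values shown sit.

As far as these compounds go, compound 2 alone carries a true number, so it remains open whether plain phenyl on this nitrogen would keep a value close to that of compound 2, which gives 26.2 nM, or whether the fluoro and methoxy groups are needed for it. From the compounds shown here alone, it also remains open where pyridin-2-yl would fall, and whether any ring with hetero atoms can give a true number here.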